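From oxolan-2-yl to methyl: compound 1 and compound 3

This account rests on a few compounds, and the source may have more. Where it says the series, first, only, none or still open, it means among the compounds named here.

In a physicochemical assay for solubility, measured as kinetic solubility (a lower number here means a less soluble compound, a higher number a more soluble compound), compound 1 `Cc1cc(C)c(CN2CCc3c(Cl)cc([C@H](CO)[C@H]4CCCO4)c(Cl)c3C2=O)c(=O)[nH]1` stands at 430000 nM on its one numeric entry. Compound 2 `COC(c1cc(Cl)c2c(c1Cl)C(=O)N(Cc1c(C)cc(C)[nH]c1=O)CC2)C1CCS(=O)(=O)CC1` carries a different group on the shared core and gives 373000 nM; 415000 nM (2 entries) within the scatter of compound 1. Compound 3 `Cc1cc(C)c(CN2CCc3c(Cl)cc([C@@H](C)CO)c(Cl)c3C2=O)c(=O)[nH]1` has methyl in place of oxolan-2-yl on a saturated chain carbon bound to an aromatic carbon and a saturated chain carbon. Among the compounds with values here, no measured pair isolates this change. With compound 2 at 373000 nM; 415000 nM (2 entries) no step beyond the scatter is expected in this assay and any drift is expected to be a small fall. The estimate means a 1.2-fold lower number from compound 1 to compound 3 (0.09 log units; within the scatter) in this read-out. For compound 3 the expected value is 350000 nM with a range from 180000 nM to 500000 nM in this estimate.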

Compound 3, solubility: 143000 nM
Compound 3: the middle estimate sits 2.4-fold (0.39 log units) above what was measured; the measured number lies below the stated range.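

In this assay, the place on a saturated chain carbon bound to an aromatic carbon and a saturated chain carbon proves responsive: methyl in place of oxolan-2-yl gives a 3.0-fold lower number from compound 1 to compound 3 (0.48 log units; beyond the scatter). Within the data shown here, this is the first step that can be read at this place, and it rests on a single pair of compounds. Repeat readings show how closely one compound agrees with itself in this assay: the several entries of compound 2 in this assay, 373000 nM; 415000 nM (2 entries)

Whether the loss of the ring or of its oxygen accounts for the step stays open. So does how an amine or a longer chain would read at this place.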